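The compounds below may be only part of what the source reports. "The series", "measured", "known", "first", "only" and "open" are said of these compounds alone.

The measured compounds:

Compound 1, `CCOC(=O)C1=C(C)NC(=S)NC1c1ccc(OC)cc1`; in a functional assay on HT-29 cells (Homo sapiens) for inhibition, read by sulforhodamine B assay, with a stated time of 48 h (on this read-out higher numbers stand for weaker inhibition of growth and lower numbers for stronger inhibition of growth), compound 1 gives 30.6 ug/mL.
Compound 2, `CCOC(=O)C1=C(C)NC(=S)NC1c1ccc(SC)cc1`; compound 2 gives 17.2 ug/mL.
Compound 3, `CCOC(=O)C1=C(C)NC(=S)NC1c1ccc(O)cc1`; compound 3 gives > 250 ug/mL, which is a limit of the assay and not a number.

Compound 3 therefore stands apart from the other two: it sits at the limit of > 250 ug/mL in this assay, at which 1 of the 3 values shown sits, and it is the only one of the three to do so. The measured steps leading to it are an at least 8.1-fold higher number from compound 1 to compound 3 (0.91 log units; beyond the scatter) and an at least 14-fold higher number from compound 2 to compound 3 (1.16 log units; beyond the scatter), both beyond the scatter, so compound 3 is the weakest inhibitor of growth among the three. Between the other two, a 1.8-fold lower number from compound 1 to compound 2 (0.25 log units; within the scatter), which lies within the scatter.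

Compound 4, `CCCc1ccc(C2NC(=S)NC(C)=C2C(=O)OCC)cc1`, has not yet been measured in this assay. Compared with compound 3, the change is propyl in place of hydroxy on an aromatic carbon.

Among the measured compounds shown here, the steps that bear on this change both run towards compound 3, and both show that the hydroxy compound gives a far higher number than a compound carrying methoxy or methylsulfanyl at the same carbon. Compound 4 moves in the opposite direction, taking the hydroxy away and putting propyl there, so a large drop in the number is expected, back towards the region of compound 1 and compound 2: an at least 10-fold lower number from compound 3 to compound 4 (1.00 log units; beyond the scatter). The estimated value for compound 4 is 25 ug/mL, within a range from 8 ug/mL to 100 ug/mL.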

Compound 4, concentration for 50% growth inhibition: 50.4 ug/mL
The estimate for compound 4 lay 2.0-fold (0.30 log units) below the measured number; measured number inside the range.
By their numbers in this assay, from the lowest: compounds 2, 1 and 4 (each within the scatter of the next, the first and the last beyond it). At a limit, above all of these: compound 3.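

In this assay, propyl brings no oxygen or sulfur to this aromatic carbon and has 0 hydrogen-bond donors and 0 hydrogen-bond acceptors, yet putting it in place of hydroxy gives an at least 4.9-fold lower number from compound 3 to compound 4 (0.69 log units; beyond the scatter), so among these compounds a measurable number at this position does not require oxygen or sulfur attached to the ring. Set against methoxy, the same propyl group gives a 1.6-fold higher number from compound 1 to compound 4 (0.22 log units; within the scatter), which leaves the two groups indistinguishable, while against methylsulfanyl it gives a 2.9-fold higher number from compound 2 to compound 4 (0.47 log units; beyond the scatter), a modest step that does go beyond the scatter. Of the four groups compared at this carbon, hydroxy is the only one that stands apart, and compound 3 alone remains at a limit of the assay rather than at a number: the limit of > 250 ug/mL in this assay, at which 1 of the 4 values shown sits.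

The compounds shown leave open why hydroxy behaves so differently, and what an amine or a carboxylic acid at this same carbon would give. They also do not tell whether a longer chain than propyl would move the number away from that of compound 4, or in which direction.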